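The source may report more compounds than this note shows. Statements on the series, on what has been measured and on what is new or still open speak of the compounds shown alone.

Compound 1: `COc1cccc(OC)c1OCCNCCOc1ccccc1OCc1ccc(C)cc1`, 9.12
Compound 2: `COc1ccccc1COc1ccccc1OCCNCCOc1c(OC)cccc1OC`, 8.86
Compound 3: `COc1cccc(COc2ccccc2OCCNCCOc2c(OC)cccc2OC)c1`, 9.12

In a functional assay on thoracic aorta for antagonist activity at Alpha-1D adrenergic receptor (Rattus norvegicus) (a lower number here means a less potent compound, a higher number a more potent compound, by a factor of ten per unit of this negative logarithm), compound 1 stands level with compound 3, the two together at the top of the three numbers, and compound 2 is the furthest from it by a number 0.26 log units lower from compound 1 to compound 2 (within the scatter); the step of no change at the digits printed from compound 1 to compound 3 (within the scatter) also stays within the scatter. Compound 4, `COc1cccc(OC)c1OCCNCCOc1ccccc1OCc1ccc(OC(C)C)cc1`, differs from compound 1 by isopropoxy in place of methyl on an aromatic carbon. No measured step touches this exact group: a number 0.26 log units lower from compound 1 to compound 2 (within the scatter), no change at the digits printed from compound 1 to compound 3 (within the scatter) and a number 0.26 log units higher from compound 2 to compound 3 (within the scatter) all change the substitution on the benzyl aryl and all stay within the scatter, so among these three compounds there is no sign of a large shift from altering it. The step in this assay is therefore expected to be a number 0.12 log units lower from compound 1 to compound 4 (within the scatter), not beyond the scatter. Compound 4 is estimated at 9, within 8.5 to 9.5.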

Compound 4, negative logarithm of the antagonist equilibrium constant: 9.14
The estimate for compound 4 lay 0.14 log units below the measured number; low and high end bracket the measured number.
By their numbers in this assay, from the lowest: compounds 2, 1, 3 and 4 (each within the scatter of the next).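

In this assay, isopropoxy in place of methyl on the aromatic carbon para to a large group gives a number 0.02 log units higher from compound 1 to compound 4 (within the scatter), so this position accepts four heavy atoms, one of them oxygen, in place of a single carbon with no shift beyond the scatter. Compound 4 also stays within the scatter of both methoxyphenyl compounds, with a number 0.02 log units higher from compound 3 to compound 4 (within the scatter) and a number 0.28 log units higher from compound 2 to compound 4 (within the scatter). Nothing else measured here bears on this result.

The compounds shown leave open whether an amine or a carboxylic acid at this position would also stay within the scatter. They also leave open what a longer chain on the oxygen would do.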